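Compound 4 Without Chlorines: Expected Vero Cell Cytotoxicity

The source may hold more compounds than are shown below. What is called first, only, known or untested is meant among the compounds shown, and "the series" means these compounds.

Compound 1 `N/C(=N/NC(CC(=O)c1ccc(-n2ccnc2)cc1)c1ccccc1Cl)c1ccccn1` gives 53200 nM in an ADME assay on Vero cells (Chlorocebus sabaeus) for cytotoxicity, read by MTT assay, with a stated time of 72 h; on this read-out lower numbers stand for higher toxicity in this test and higher numbers for lower toxicity in this test.
Compound 2 `N/C(=N/NC(CC(=O)c1ccc(-n2ccnc2)cc1)c1ccc(Cl)cc1Cl)c1ccccn1` gives 27800 nM in this assay.
Compound 3 `N/C(=N/NC(CC(=O)c1ccc(-n2ccnc2)cc1)c1ccccc1Br)c1ccccn1` gives 29000 nM in this assay.

Compound 2 has the lowest of the three numbers, but none of the spread is meaningful: its nearest neighbour is compound 3, with a 1.0-fold higher number from compound 2 to compound 3 (0.02 log units; within the scatter), and the widest gap is to compound 1, where the step of a 1.9-fold lower number from compound 1 to compound 2 (0.28 log units; within the scatter) still stays within the scatter. On these three compounds the shared core tolerates changes on the saturated chain carbon bound to an amine nitrogen without any clear shift in this assay.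

Compound 4 `N/C(=N/NC(CC(=O)c1ccc(-n2ccnc2)cc1)c1ccccc1)c1ccccn1` is not yet measured. The change from compound 2 is phenyl in place of 2,4-dichlorophenyl on a saturated chain carbon bound to an amine nitrogen and a saturated chain carbon. The step that bears on it most directly runs the opposite way: going from compound 1 to compound 2 added a chloro and gave a 1.9-fold lower number from compound 1 to compound 2 (0.28 log units; within the scatter), within the scatter. Removing both chlorines is therefore expected to move the number back, at most modestly, toward that of compound 1, so that the step of a 1.7-fold higher number from compound 2 to compound 4 (0.24 log units; within the scatter) is expected and compound 4 is estimated at 48000 nM, with a range from 24000 nM to 96000 nM.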

Compound 4, half-maximal cytotoxic concentration: 63500 nM
Compound 4: middle estimate off by 1.3-fold (0.12 log units), on the low side; low and high end bracket the measured number.
By their numbers in this assay, from the lowest: compounds 2, 3, 1 and 4 (each within the scatter of the next, the first and the last beyond it).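

For the compounds shown here, compound 4, with phenyl on the saturated chain carbon bound to an amine nitrogen and a saturated chain carbon, yields the first steps in this assay that lie beyond the scatter: a 2.3-fold higher number from compound 2 to compound 4 (0.36 log units; beyond the scatter) with phenyl in place of 2,4-dichlorophenyl, and a 2.2-fold higher number from compound 3 to compound 4 (0.34 log units; beyond the scatter) with hydrogen in place of bromo. This place therefore does register a change on this read-out, a modest one, and in both steps the number moves toward lower toxicity in this test once the halogens are gone. The pattern does not hold for every halogen, and compound 1 goes against it: once its chloro is gone, a 1.2-fold higher number from compound 1 to compound 4 (0.08 log units; within the scatter) stays within the scatter.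

The compounds shown leave open whether a carboxylic acid or an amine in place of the phenyl on this saturated chain carbon would shift the number in this assay any further. Nothing given here accounts for the steps seen with compound 4.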